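The source may report more compounds than this note shows. Statements on the series, on what has been measured and on what is new or still open speak of the compounds shown alone.

In a functional assay on MCF7 cells (Homo sapiens) for cytotoxicity, read by MTT assay, with a stated time of 96 h (on this read-out lower numbers stand for stronger inhibition and higher numbers for weaker inhibition), three compounds that differ only in the group on the aromatic nitrogen of a shared core have been measured. Compound 1 `COc1ccccc1-n1cc(C(=O)c2cc(OC)c(OC)c(OC)c2)c(-c2ccccc2)c1` gives 150 nM, compound 2 `COc1cc(C(=O)c2cn(-c3cccc(Br)c3)cc2-c2ccccc2)cc(OC)c1OC` gives 78 nM, and compound 3 `COc1cc(C(=O)c2cn(-c3ccc(Cl)cc3)cc2-c2ccccc2)cc(OC)c1OC` gives 140 nM. Compound 1 thus stands within the scatter of both other compounds, and the three values do not separate.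

Compound 4 `COc1cc(C(=O)c2cn(-c3ccc(N)cc3)cc2-c2ccccc2)cc(OC)c1OC` has not yet been measured. It carries 4-aminophenyl in place of the 2-methoxyphenyl of compound 1, on the same aromatic nitrogen: 4-aminophenyl in place of 2-methoxyphenyl on an aromatic nitrogen.

Three measured steps at this place bear on the change: a 1.9-fold lower number from compound 1 to compound 2 (0.28 log units; within the scatter), a 1.1-fold lower number from compound 1 to compound 3 (0.03 log units; within the scatter) and a 1.8-fold higher number from compound 2 to compound 3 (0.25 log units; within the scatter). Each lies within the scatter, so exchanging these groups has not yet moved the number measurably. Among the compounds with values here, compound 3, with its 4-chlorophenyl, offers the closest named comparison, but no measured compound carries a 4-aminophenyl group, so the uncertainty remains wide.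

In this assay, no step beyond the scatter is therefore expected, with only a slight lean toward a lower number. The expected step is a 1.7-fold lower number from compound 1 to compound 4 (0.22 log units; within the scatter). For compound 4 the estimated value is 90 nM, with an expected range from 20 nM to 250 nM.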

Compound 4, half-maximal inhibitory concentration: 35 nM
For compound 4 the middle estimate is 2.6-fold (0.41 log units) above the measured one, and the stated range covers the measured number.
By their numbers in this assay, from the lowest: compound 4; then compounds 2, 3 and 1 (each within the scatter of the next).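

In this assay, the group on the aromatic nitrogen, which had not yet moved the number measurably, now does so: 4-aminophenyl in place of 2-methoxyphenyl gives a 4.3-fold lower number from compound 1 to compound 4 (0.63 log units; beyond the scatter). The change of amino in place of chloro on an aromatic carbon, the only difference between these two compounds, gives a 4.0-fold lower number from compound 3 to compound 4 (0.60 log units; beyond the scatter), and 4-aminophenyl in place of 3-bromophenyl gives a 2.2-fold lower number from compound 2 to compound 4 (0.35 log units; beyond the scatter), so compound 4 has the lowest number of the four and the change at this position is no longer lost in the scatter. Nothing measured here accounts for these steps.

The compounds shown leave open whether this lower number is specific to the amino group, since no compound here carries a dimethylamino, acetamido or hydroxyl group at the same place on the phenyl ring. They also leave open whether an amino group elsewhere on that ring would give a similar number, and whether the step holds on any core other than the shared one.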